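Swapping a Methyl for Fluoro on the Aryl Urea

A few compounds are considered here, and "the series" means these few. Any claim that something is new, unique, unknown or untested is made for them only; others in the source may bear on it.

Measured so far:
compound 1 `Cc1cccc(NC(=O)Nc2nnc(Sc3ncnc4scc(-c5ccncc5)c34)s2)c1` — 20700 nM
compound 2 `Cc1ccc(NC(=O)Nc2nnc(Sc3ncnc4scc(-c5ccncc5)c34)s2)cc1` — 52000 nM

In a functional assay on HepG2 cells (Homo sapiens) for antiproliferative activity, read by MTT assay, with a stated time of 48 h (on this read-out higher numbers stand for weaker inhibition and lower numbers for stronger inhibition), compound 1 gives 20700 nM, the lowest of the two numbers seen, and compound 2 gives 52000 nM. Going by the values given here, the only measured step is a 2.5-fold higher number from compound 1 to compound 2 (0.40 log units; beyond the scatter), a change of where the methyl sits on the outer ring, not of what the group is.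

Compound 3 `O=C(Nc1cccc(F)c1)Nc1nnc(Sc2ncnc3scc(-c4ccncc4)c23)s1` keeps the shared core of compound 1 and differs from it only at the outer ring: fluoro in place of methyl on an aromatic carbon. The group stays in the same place; only its identity changes. Among the compounds with values here, no measured pair in this set shows a methyl exchanged for a fluoro, so there is no step that speaks directly to this change. Within the data shown here, the one step available shows that the outer ring is sensitive to even a modest change, but it gives no direction for this one.

On that basis compound 3 is expected to land near compound 1, with a 1.2-fold higher number from compound 1 to compound 3 (0.08 log units; within the scatter) expected to stay within the scatter. The estimate for compound 3 is 25000 nM, with a range from 10000 nM to 60000 nM.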

Compound 3, half-maximal inhibitory concentration: 64100 nM
Beside the measured number, compound 3's estimate is 2.6-fold (0.41 log units) below it; measured number above the stated range.
By their numbers in this assay, from the lowest: compound 1; then compounds 2 and 3 (each within the scatter of the next).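

In this assay, the outer ring responds not only to where the methyl sits but also to what the group is. Putting fluoro in place of the methyl of the 3-methylphenyl group swaps one heavy atom for one heavy atom, with no change in hydrogen-bond donors, acceptors or net charge, and still gives a 3.1-fold higher number from compound 1 to compound 3 (0.49 log units; beyond the scatter) on this read-out. The other comparison, a 1.2-fold higher number from compound 2 to compound 3 (0.09 log units; within the scatter), shows no difference that can be read, so both single changes tried on the 3-methylphenyl group give higher numbers and leave the two changed compounds indistinguishable, while nothing measured here bears on the reason for the step.

From the compounds shown here alone, what remains open is whether the methyl itself helps or the fluoro hurts, which a plain phenyl ring carrying only hydrogen at this place would help to separate. Also open, going by these compounds, is how other groups on the same ring carbon, such as chloro, methoxy or trifluoromethyl, would compare with the methyl and the fluoro.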